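This account rests on a few compounds, and the source may have more. Where it says the series, first, only, none or still open, it means among the compounds named here.

Measured so far:
- compound 1 `COc1ccc(C(=O)/C=C/c2cc(-c3cc(OC)c(OC)c(OC)c3)n[nH]2)cc1OC`: 19400 nM
- compound 2 `COc1ccc(C(=O)/C=C/c2cc(-c3cc(OC)c(OC)c(OC)c3)n[nH]2)cc1`: > 100000 nM

Among the measured compounds shown here, in a functional assay on CAKI-1 cells (Homo sapiens) for inhibition, read by sulforhodamine B assay, with a stated time of 48 h (a lower number here means that less compound is tolerated, a higher number that more compound is tolerated), compound 1 gives 19400 nM, the only plain number in the set. Compound 2, in this assay, is reported only as a limit, > 100000 nM, and not as a number. For the measured compounds named here, the step between them, an at least 5.1-fold higher number from compound 1 to compound 2 (0.71 log units; beyond the scatter), is the sole measured step, and it runs in the direction of removing a methoxy group; its size is bounded by the limit of > 100000 nM in this assay, at which 1 of the 2 values shown sits, so the true gap may be larger than stated.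

Compound 3 `COc1cc(C(=O)/C=C/c2cc(-c3cc(OC)c(OC)c(OC)c3)n[nH]2)cc(OC)c1OC` has not yet been tested in this assay. Going by the values given here, its change from compound 1 is methoxy in place of hydrogen on an aromatic carbon, a methoxy in place of hydrogen on an aromatic carbon, which is the reverse of the one measured step. Taking that step as the only guide, adding a methoxy is expected to move the number down, or at most to leave it within the scatter, rather than up. Compound 3 is therefore expected to give 10000 nM in this assay, with a range from 4000 nM to 30000 nM, an expected step of a 1.9-fold lower number from compound 1 to compound 3 (0.29 log units; within the scatter).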

Compound 3, concentration lethal to 50% of the cells: 35500 nM
For compound 3 the middle estimate is 3.6-fold (0.55 log units) below the measured one; measured number above the stated range.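

Placing a methoxy in place of hydrogen on the aromatic carbon ortho to a methoxy group and meta to a large group gives a 1.8-fold higher number from compound 1 to compound 3 (0.26 log units; within the scatter), so compound 1 and compound 3 cannot be told apart in this assay. Among the compounds shown here, the only earlier step, an at least 5.1-fold higher number from compound 1 to compound 2 (0.71 log units; beyond the scatter), lies beyond the scatter and comes from taking a methoxy group away, so this new step adds the first evidence on what happens when one is added to the same ring. Across these three compounds, the one change that gives a step beyond the scatter is the removal of a methoxy group from compound 1, while the addition of one at this position gives no step that can be separated from the scatter, and the two changes therefore do not behave as simple opposites.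

Compound 2 is reported only as a limit, so the full size of the step that removes a methoxy group remains open: the limit of > 100000 nM in this assay, at which 1 of the 3 values shown sits. The compounds shown also leave open what a hydroxy group, a fluorine atom, an amine or a longer alkoxy chain would do at this position, since methoxy and hydrogen are the only two groups seen there.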